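Removing the aromatic ring from the amine side chain

The source may hold more compounds than are shown below. What is called first, only, known or untested is meant among the compounds shown, and "the series" means these compounds.

Compound 1 `COc1ccc(CNc2cc(Oc3ccc(NC(=O)Nc4ccc(C)c(C(F)(F)F)c4)cc3)ncn2)cc1` carries a (4-methoxybenzyl)amino group on its shared core. In a functional assay on BaF3 cells (Mus musculus) for inhibition, read by CCK-8 assay, with a stated time of 72 h (on this read-out lower numbers stand for stronger inhibition of growth and higher numbers for weaker inhibition of growth), compound 1 gives 1000 nM, the lowest number among the two compounds measured. Its nearest neighbour is compound 2 `Cc1ccc(NC(=O)Nc2ccc(Oc3cc(/N=C/N(C)C)ncn3)cc2)cc1C(F)(F)F`, in which the aromatic ring of that side chain is gone; in this assay compound 2 gives 6610 nM. Within the data shown here, the only measured step, a 6.6-fold higher number from compound 1 to compound 2 (0.82 log units; beyond the scatter), shows that taking the ring-bearing group away and putting a small ring-free group on the same aromatic carbon weakened the inhibition of growth.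

Compound 3 `CCC(=O)Nc1cc(Oc2ccc(NC(=O)Nc3ccc(C)c(C(F)(F)F)c3)cc2)ncn1` makes a change of the same kind: propanoyl in place of 4-methoxybenzyl on a nitrogen on an aromatic ring. Here too the ring-bearing group is exchanged for a short ring-free group, though the entering group is a propanoyl rather than the group found in compound 2. Among the measured compounds shown here, because the one step on record, a 6.6-fold higher number from compound 1 to compound 2 (0.82 log units; beyond the scatter), runs in the weakening direction, a step of similar sign but perhaps smaller size is expected here. The expected step is a 3.0-fold higher number from compound 1 to compound 3 (0.48 log units; beyond the scatter). Compound 3 is therefore estimated at 3000 nM, with a range from 1000 nM to 10000 nM.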

Compound 3, concentration for 50% growth inhibition: 990 nM
The estimate for compound 3 lay 3.0-fold (0.48 log units) above the measured number; the measured number lies below the stated range.
By their numbers in this assay, from the lowest: compounds 3 and 1 (each within the scatter of the next); then compound 2.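

The aromatic ring of the side chain turns out not to be required at this position: putting propanoyl in place of 4-methoxybenzyl on the nitrogen gives a 1.0-fold lower number from compound 1 to compound 3 (0.00 log units; within the scatter) in this assay and so leaves the number unchanged within the scatter. Losing the ring is therefore not enough on its own to weaken the inhibition of growth, since two ring-free groups of equal heavy-atom count on the same aromatic carbon still differ, with a 6.7-fold lower number from compound 2 to compound 3 (0.82 log units; beyond the scatter) as the step between them. What counts here is which small group is attached, not merely whether a ring is present. Nothing shown here gives a reason for this difference.

The compounds shown do not separate the part played by the carbonyl of propanoyl from that of its chain, and a plain propyl group on the same nitrogen would test this directly. Also open, on these data alone, is how far the number stays flat with other acyl groups, such as the shorter acetyl, the longer butanoyl, or a benzoyl that brings an aromatic ring back.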